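The source may hold more compounds than are shown below. What is called first, only, known or untested is meant among the compounds shown, and "the series" means these compounds.

In a functional assay on B16-F10 cells (Mus musculus) for antiproliferative activity, read by MTT assay, with a stated time of 72 h (a higher number here means a weaker inhibitor, a lower number a stronger inhibitor), three compounds sharing a core have been measured. For the measured compounds named here, compound 3 `CCCCCCCCCCCNC[C@@H]1OC[C@H](N)[C@H]1O` gives 88800 nM, the only actual number among them. Compound 1 `CCCCCCCCNC[C@@H]1OC[C@H](N)[C@@H]1O` gives > 128000 nM, which is a limit of the assay and not a number. Compound 2 `CCCCCCCNC[C@@H]1OC[C@H](N)[C@H]1O` gives > 128000 nM, which is likewise a limit.

Compound 4 `CCCCCCCCNC[C@@H]1OC[C@H](N)[C@H]1O` has not yet been measured. It differs from compound 3 as follows: hydrogen in place of propyl on a saturated chain carbon, eight bonds along the chain from an amine nitrogen. In words, it carries hydrogen in place of propyl on a saturated chain carbon, eight bonds along the chain from an amine nitrogen.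

Going by the values given here, one measured step bears on this change: an at least 1.4-fold lower number from compound 2 to compound 3 (0.15 log units; that floor lies within the scatter). That step put butyl in place of hydrogen, whereas the new change takes propyl away, so it points toward a higher number for compound 4. The size of that step is only a floor, set by the limit of > 128000 nM in this assay, at which 2 of the 3 values shown sit.

A modest move toward a higher number is therefore expected in this assay, and it may not clear the scatter. The expected step is a 1.5-fold higher number from compound 3 to compound 4 (0.18 log units; within the scatter). Compound 4 is estimated at 135000 nM, with an expected range of 85000 nM to 220000 nM, and it may well be reported only as a limit.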

Compound 4, half-maximal inhibitory concentration: > 128000 nM
Compound 4: only a limit was reported; the forecaster's own chance of this, stated with the estimate: 70%; the middle value does not contradict the limit.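

In this assay the loss of propyl from a saturated chain carbon, eight bonds along the chain from an amine nitrogen, comes out as an at least 1.4-fold higher number from compound 3 to compound 4 (0.15 log units; that floor lies within the scatter) and leaves compound 4 with a limit rather than a number. This means that compound 3 now stands apart from two compounds with shorter chains, compound 2 and compound 4, yet each of those steps gives only a floor, and the true size remains hidden: the limit of > 128000 nM in this assay, at which 3 of the 4 values shown sit. Compound 4 also forms a pair with compound 1 for judging the drawn configuration, but the steps from compound 2 and from compound 1 to compound 4 cannot be read, so no effect of that configuration can be stated for the pair: the fact that compounds 1 and 4 differ only in the configuration as drawn.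

For the compounds shown here, compound 3 is the only compound here with an actual number, and whether a longer chain than its own would bring the number lower remains open. Also open, as far as these compounds go, is how the other drawn configuration would read on the chain of compound 3, and whether a hydroxyl group at the chain end would keep its number.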